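Back from ortho-chloro to a para group on the benzyl

A few compounds are considered here, and "the series" means these few. Any claim that something is new, unique, unknown or untested is made for them only; others in the source may bear on it.

Measured compounds in this series:
compound 1 `Cc1ccc(Cn2cc(COc3ccc4c(=O)ccoc4c3)nn2)cc1`: > 100000 nM
compound 2 `O=c1ccoc2cc(OCc3cn(Cc4ccc(Cl)cc4)nn3)ccc12`: > 100000 nM
compound 3 `O=c1ccoc2cc(OCc3cn(Cc4ccccc4Cl)nn3)ccc12`: 15100 nM

In a functional assay on MDA-MB-231 cells (Homo sapiens) for cytotoxicity, read by MTT assay, with a stated time of 48 h (on this read-out higher numbers stand for weaker inhibition and lower numbers for stronger inhibition), compound 1 reaches only the assay limit, > 100000 nM. Compound 2 likewise stops at the limit, > 100000 nM. Compound 3 alone gives a number, 15100 nM. Both steps leading to it start from the limit of > 100000 nM in this assay, at which 2 of the 3 values shown sit: an at least 6.6-fold lower number from compound 1 to compound 3 (0.82 log units; beyond the scatter) and an at least 6.6-fold lower number from compound 2 to compound 3 (0.82 log units; beyond the scatter), each beyond the scatter.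

Compound 4 is `N#Cc1ccc(Cn2cc(COc3ccc4c(=O)ccoc4c3)nn2)cc1`; it differs from compound 3 in that (4-cyanophenyl in place of 2-chlorophenyl on a saturated chain carbon bound to an aromatic nitrogen). The 4-cyanophenyl resembles the 4-methylphenyl of compound 1 and the 4-chlorophenyl of compound 2 more than the 2-chlorophenyl of compound 3, so the two measured steps are expected to run backwards: the number for compound 4 is expected to rise by a 5.3-fold higher number from compound 3 to compound 4 (0.72 log units; beyond the scatter), quite possibly back to the limit. Compound 4 is estimated at 80000 nM, between 20000 nM and 250000 nM.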

Compound 4, half-maximal inhibitory concentration: > 100000 nM
Compound 4 was reported as a limit (the forecaster's own chance of this, stated with the estimate: 55%); middle value at least 1.2-fold (0.09 log units) from the limit.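

In this assay the change from 2-chlorobenzyl to 4-cyanobenzyl gives an at least 6.6-fold higher number from compound 3 to compound 4 (0.82 log units; beyond the scatter). Compound 4 gives > 100000 nM, which is a limit, so the 4-cyanophenyl joins the 4-methylphenyl of compound 1 and the 4-chlorophenyl of compound 2 in yielding no number. The steps from compound 1 and from compound 2 to compound 4 cannot be read, and the series stays capped: the limit of > 100000 nM in this assay, at which 3 of the 4 values shown sit.

The compounds shown leave open whether the number of compound 3 goes with the chloro group itself or with its place on the ring. They also leave open how a benzyl carrying an amine or a carboxylic acid would read.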